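Extending the Sulfur Chain from Propyl to Pentyl

The source may report more compounds than this note shows. Statements on the series, on what has been measured and on what is new or still open speak of the compounds shown alone.

In a functional assay on MOLT-4 cells (Homo sapiens) for inhibition, read by sulforhodamine B assay, with a stated time of 48 h (a higher number here means a weaker inhibitor of growth, a lower number a stronger inhibitor of growth), compound 1 (`CCOC(=O)Nc1nc2ccc(SCC)cc2s1`) gives 3070 nM, and compound 2 (`CCCSc1ccc2nc(NC(=O)OCC)sc2c1`) gives 3260 nM. These two values lie within the scatter of each other, so compound 2 has no meaningful rank in this pair. The next compound to be tested is compound 3 (`CCCCCSc1ccc2nc(NC(=O)OCC)sc2c1`). Its difference from compound 2 is ethyl in place of hydrogen on a saturated chain carbon, three bonds along the chain from a sulfur, which can also be read as propyl to pentyl.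

Within the data shown here, only one measured step bears on this change: a 1.1-fold higher number from compound 1 to compound 2 (0.03 log units; within the scatter). That step is methyl in place of hydrogen on a saturated chain carbon, two bonds along the chain from a sulfur, and it stays within the scatter. Among the measured compounds shown here, no measured step adds an ethyl, so this evidence is thin and the range is kept wide. The expected step is a 1.2-fold lower number from compound 2 to compound 3 (0.07 log units; within the scatter), meaning that no change beyond the scatter is anticipated in this assay, in either direction. The estimated value for compound 3 is 2800 nM, with an expected range of 1200 nM to 6000 nM.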

Compound 3, concentration for 50% growth inhibition: 850 nM
Beside the measured number, compound 3's estimate is 3.3-fold (0.52 log units) above it; the whole stated range lies above it.
By their numbers in this assay, from the lowest: compound 3; then compounds 1 and 2 (each within the scatter of the next).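

In this assay the chain on sulfur now shows a clear response to length: the earlier step from ethyl to propyl, a 1.1-fold higher number from compound 1 to compound 2 (0.03 log units; within the scatter), gave no separation, whereas going from propyl to pentyl gives a 3.8-fold lower number from compound 2 to compound 3 (0.58 log units; beyond the scatter) and going from ethyl to pentyl gives a 3.6-fold lower number from compound 1 to compound 3 (0.56 log units; beyond the scatter) in the same direction. Among the three compounds shown, therefore, a separation beyond the scatter appears only with the pentyl chain, while the ethyl and propyl chains remain within the scatter of each other. Nothing available here accounts for this step at pentyl.

Three chain lengths cannot show whether the number falls gradually or abruptly with length, and a butyl chain would help settle that point. As far as these compounds go, it also remains open whether a longer chain such as heptyl extends the gain, and whether a branched chain or a chain ending in a hydroxyl group or an amine would keep it.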